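The source may report more compounds than this note shows. Statements on the series, on what has been measured and on what is new or still open speak of the compounds shown alone.

Working notes on the series. Compound 1 `COc1ccc(NC(=O)CSc2nc3c(N)ncnc3[nH]2)cc1OC` gives 18000 nM in an assay on isolated protein for inhibition of Ectonucleotide pyrophosphatase/phosphodiesterase family member 1 (Homo sapiens), using Lineweaver-Burk analysis; a lower number here means a stronger inhibitor, a higher number a weaker inhibitor. Compound 2 `COc1ccc(NC(=O)CSc2nc3cnccc3[nH]2)cc1OC` gives 29200 nM in this assay, and compound 3 `COc1ccc(NC(=O)CSc2nc3cc(Br)cnc3[nH]2)cc1OC` gives 10800 nM. Compound 1 thus holds the second highest of the three numbers, but its differences to both compound 2 and compound 3 fall within the scatter, so no order among the three can be read from these values.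

Compound 4 `COc1ccc(NC(=O)CSc2nc3c(N)nc(SC)nc3[nH]2)cc1OC` is not yet measured. It differs from compound 1 by methylsulfanyl in place of hydrogen on an aromatic carbon. Within the data shown here, no comparable step exists among the measured compounds, so the direction is open. A small change, not clearly beyond the scatter, is expected: the step from compound 1 to compound 4 is estimated at a 1.4-fold lower number from compound 1 to compound 4 (0.14 log units; within the scatter). Compound 4 is therefore expected near 13000 nM, within 5000 nM to 35000 nM.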

Compound 4, inhibition constant: 26700 nM
For compound 4 the middle estimate is 2.1-fold (0.31 log units) below the measured one; the range from low to high includes it.
By their numbers in this assay, from the lowest: compounds 3, 1, 4 and 2 (each within the scatter of the next, the first and the last beyond it).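

Among these compounds, on the aromatic carbon between two ring nitrogen atoms, methylsulfanyl in place of hydrogen gives a 1.5-fold higher number from compound 1 to compound 4 (0.17 log units; within the scatter) in this assay and so is the first direct reading at this position. The two added heavy atoms, carbon and sulfur, bring no change that can be told from the scatter. No available measurement offers an explanation for this result.

Going by these compounds, whether a carboxylic acid, a dimethylamino group or a longer alkylsulfanyl chain at this position would move the number beyond the scatter remains open. Also open, on these data alone, is whether the methylsulfanyl step would hold on a core without the amino group.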